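Unsubstituted anilino on the cinnamamide linker: expectation before measurement

A few compounds are considered here, and "the series" means these few. Any claim that something is new, unique, unknown or untested is made for them only; others in the source may bear on it.

The study measures antiproliferative activity in a functional assay on NCI-H460 cells (Homo sapiens) for antiproliferative activity, read by CCK-8 assay, with a stated time of 72 h, tested at 2 uM; a lower number here means a weaker effect, a higher number a stronger effect of the compound at the concentration tested. Compound 1 `Nc1ccccc1NC(=O)c1ccc(Cn2cnc3c(Nc4ccccc4)nc(Cl)nc32)cc1` gives 42.7% in this assay. Compound 2 `Nc1ccccc1NC(=O)/C=C/c1ccc(Cn2cnc3c(Nc4cccc(OC(F)(F)F)c4)nc(Cl)nc32)cc1` gives 2.1% in this assay, the lowest of the two numbers shown, with compound 1 standing a distance above it that lies beyond the usual scatter. Compound 3 `Nc1ccccc1NC(=O)/C=C/c1ccc(Cn2cnc3c(Nc4ccccc4)nc(Cl)nc32)cc1` has not yet been measured. It differs from compound 2 in one place: hydrogen in place of trifluoromethoxy on an aromatic carbon, on an aromatic carbon of a six-membered aromatic ring of carbon only, meta to a large group. Going by the values given here, compound 3 thus carries the anilino of compound 1 on the linker of compound 2, and no measured pair separates the two changes. Compound 3 is expected to move upward from compound 2 by a number 17.9 percentage points higher from compound 2 to compound 3 (beyond the scatter) in this assay, since the shared anilino is found in compound 1 at 42.7%. Compound 3 is therefore estimated at 20%, within a range from 2% to 45%.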

Compound 3, a percentage reported as inhibition, at one concentration (the size of the read-out at that concentration, not a potency): 2.05%
For compound 3 the middle estimate is 18 percentage points above the measured one, within the range that was stated.
By their numbers in this assay, from the lowest: compounds 3 and 2 (each within the scatter of the next); then compound 1.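

In this assay, hydrogen in place of trifluoromethoxy on an aromatic carbon, meta to a large group, gives a number 0.1 percentage points lower from compound 2 to compound 3 (within the scatter) and so shows no readable effect of that group at this position when the ethenyl linker is present. With the anilino held the same, 2-((2-aminophenyl)carbamoyl)ethenyl in place of (2-aminophenyl)carbamoyl gives a number 40.7 percentage points lower from compound 1 to compound 3 (beyond the scatter) and so ties the gap to compound 1 to the linker change, not to trifluoromethoxy. Nothing shown explains why the linker change has this effect.

As far as these compounds go, whether trifluoromethoxy would alter the read-out on the linker of compound 1 remains open. Also open, from the compounds shown here alone, are how a methoxy group or a chlorine at the same carbon would read, and whether a saturated ethyl chain in place of the ethenyl would behave like either linker.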